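Notes on 4-methylphenyl in place of 3-aminophenyl

The compounds below may be only part of what the source reports. "The series", "measured", "known", "first", "only" and "open" are said of these compounds alone.

In a functional assay on SK-OV-3 cells (Homo sapiens) for inhibition, read by CCK-8 assay, with a stated time of 70 h (on this read-out higher numbers stand for weaker inhibition and lower numbers for stronger inhibition), compound 3 `Nc1cccc(COc2ccc(OCCOCCNC3CCCC3)cc2)c1` gives 10800 nM and compound 1 `COc1ccc(COc2ccc(OCCOCCNC3CCCC3)cc2)cc1` gives 15700 nM, two values within the scatter of each other. Compound 2 `O=C(O)c1ccccc1COc1ccc(OCCOCCNC2CCCC2)cc1` reads > 100000 nM, which is a limit of the assay. The steps of an at least 6.3-fold higher number from compound 1 to compound 2 (0.80 log units; beyond the scatter) and an at least 9.2-fold lower number from compound 2 to compound 3 (0.96 log units; beyond the scatter) lie beyond the scatter, and both involve its 2-carboxyphenyl. Compound 4 `Cc1ccc(COc2ccc(OCCOCCNC3CCCC3)cc2)cc1` carries 4-methylphenyl in place of 3-aminophenyl on a saturated chain carbon bound to an oxygen on an aromatic ring. Neither group is 2-carboxyphenyl, so the nearest guide is compound 1, with a 1.5-fold lower number from compound 1 to compound 3 (0.16 log units; within the scatter). The expected step, a 1.2-fold higher number from compound 3 to compound 4 (0.08 log units; within the scatter), is estimated to stay within the scatter. The estimate for compound 4 is 13000 nM, with an expected range of 6500 nM to 26000 nM.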

Compound 4, half-maximal inhibitory concentration: 17200 nM
The estimate for compound 4 lay 1.3-fold (0.12 log units) below the measured number; the range from low to high includes it.
By their numbers in this assay, from the lowest: compounds 3, 1 and 4 (each within the scatter of the next). At a limit, above all of these: compound 2.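

In this assay, 4-methylphenyl carries no hydrogen-bond donor or acceptor, whereas 3-aminophenyl carries one of each, yet the change gives a 1.6-fold higher number from compound 3 to compound 4 (0.20 log units; within the scatter). Methyl in place of methoxy on an aromatic carbon gives a 1.1-fold higher number from compound 1 to compound 4 (0.04 log units; within the scatter), so no difference separates these three groups at this position. Only 2-carboxyphenyl stands apart, with an at least 5.8-fold lower number from compound 2 to compound 4 (0.76 log units; beyond the scatter), and the value of compound 2 is a limit of the assay: the limit of > 100000 nM in this assay, at which 1 of the 4 values shown sits.

Still open, on these data alone, is whether the carboxylic acid itself sets compound 2 apart. A methyl ester or an amide on the same phenyl would speak to that.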